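A few compounds are considered here, and "the series" means these few. Any claim that something is new, unique, unknown or untested is made for them only; others in the source may bear on it.

Measured compounds in an ADME assay on CHO cells (Cricetulus griseus) for cytotoxicity, read by MTT assay; a lower number here means a stronger inhibitor, a higher number a weaker inhibitor:
- compound 1, `CS(=O)(=O)c1cccc(Nc2ccc3nccc(-c4ccncc4)c3n2)c1`: > 50000 nM
- compound 2, `NS(=O)(=O)c1cccc(-c2ccc3nccc(-c4ccncc4)c3n2)c1`: 2000 nM
- compound 3, `O=S(=O)(NCc1ccccc1)c1cccc(Nc2ccc3nccc(-c4ccncc4)c3n2)c1`: > 50000 nM

Compound 1 gives > 50000 nM in this assay, which is a limit of the assay and not a number. Compound 3 likewise gives > 50000 nM, again a limit. Among the measured compounds shown here, compound 2 gives 2000 nM and thus stands as the only number in the set. For compound 1 and compound 3 only limits are shown. For the measured compounds named here, the one measured step between neighbours, a step that the two limits leave unreadable from compound 1 to compound 3, cannot be read because the limit of > 50000 nM in this assay, at which 2 of the 3 values shown sit, holds both ends of it, so it says nothing about the size of any change.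

Compound 4, `CS(=O)(=O)Nc1cccc(-c2ccc3nccc(-c4ccncc4)c3n2)c1`, has not yet been measured. It differs from compound 2 as follows: methanesulfonamido in place of sulfamoyl on an aromatic carbon. Going by the values given here, no measured step touches the sulfamoyl or methanesulfonamido position, and the only readable anchor is the number for compound 2. The expectation therefore rests on compound 2 alone, with no direction supported by the data, and the step of a 2.0-fold higher number from compound 2 to compound 4 (0.30 log units; within the scatter) is estimated to stay within the scatter of the assay.

For compound 4 the expected value in this assay is 4000 nM, within a range of 1000 nM to 30000 nM.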

Compound 4, half-maximal inhibitory concentration: 13000 nM
Compound 4: middle estimate off by 3.3-fold (0.51 log units), on the low side; the measured number falls inside the stated range.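

In this assay this position now carries the first readable step, a 6.5-fold higher number from compound 2 to compound 4 (0.81 log units; beyond the scatter) for methanesulfonamido in place of sulfamoyl on an aromatic carbon. The read-out moves beyond the scatter although the hydrogen-bond donor and acceptor counts and the lack of net charge are the same for the two groups, so those counts alone do not track this change. With compound 4 the set also gains a second true number, and the series no longer rests on compound 2 as its only readable anchor.

On these data alone, how an amine, a carboxylic acid or a longer chain such as ethanesulfonamido would read on this aromatic carbon remains open, as does whether the direction of this one step would hold for any of them. Compound 1 and compound 3 both remain limits and not numbers, and the step between them cannot be read, which leaves the effect of benzylamino on the sulfonyl sulfur open: the limit of > 50000 nM in this assay, at which 2 of the 4 values shown sit.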